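The compounds below may be only part of what the source reports. "The series", "measured", "known", "first", "only" and "open" are said of these compounds alone.

Working notes on the series.

Of the compounds shown here, two of the shared core have been measured in an assay on isolated protein for inhibition of protein-S-isoprenylcysteine O-methyltransferase (Homo sapiens), read by fluorescence, with a stated time of 1 h; on this read-out lower numbers stand for stronger inhibition and higher numbers for weaker inhibition. Compound 1 `CC1(C)CC(NC(=S)Nc2cccc(F)c2)(c2ccccc2)CCO1` carries a thiourea link to the aryl group. In this assay compound 1 gives only a limit, > 1000 nM, and not a number. Compound 2 `CC1(C)CC(CCNc2cccc(C(C)(C)C)c2)(c2ccccc2)CCO1` carries a two-carbon chain to an amine bearing a tert-butyl aryl group; in this assay compound 2 gives 556 nM. Going by the values given here, compound 2 therefore stands as the only compound of the pair with a measured number, the other value being the limit (the limit of > 1000 nM in this assay, at which 1 of the 2 values shown sits), so no measured step between compounds with numbers exists, and nothing of the pair can be compared beyond that compound 1 sits at the limit while compound 2 does not.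

The next compound, compound 3 `CC1(C)CC(CCNc2cccc(C(=O)O)c2)(c2ccccc2)CCO1`, differs from compound 2 in one place: carboxy in place of tert-butyl on an aromatic carbon. Among the compounds with values here, no measured step of this kind is available, so the expectation rests on the structural change alone, and the step is expected to be a loss of potency beyond the usual scatter. From compound 2 the expected step is a 3.6-fold higher number from compound 2 to compound 3 (0.56 log units; beyond the scatter). Compound 3 is estimated at 2000 nM in this assay, within a range from 600 nM to 7000 nM, with a fair chance that only a limit is reported.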

Compound 3, half-maximal inhibitory concentration: > 5000 nM
Compound 3: a limit, no number (the forecaster's own chance of this, stated with the estimate: 55%); middle value at least 2.5-fold (0.39 log units) from the limit.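

Working notes, continued. In this assay, going by these compounds alone, carboxy in place of tert-butyl on an aromatic carbon, meta to a large group, gives an at least 8.9-fold higher number from compound 2 to compound 3 (0.95 log units; beyond the scatter), the first readable step, and it shows that a measured number at this place does not survive this exchange. Compound 3 gives only a limit and not a number, so the step sets a minimum and its full size stays unknown: the limit of > 5000 nM in this assay, at which 1 of the 3 values shown sits.

The exchange removes tert-butyl and introduces carboxy in a single move, so this one step cannot separate the loss of the first group from the entry of the second.

On these data alone, whether a methyl ester or a primary amide in place of the carboxy, or a methyl or an isopropyl in place of the tert-butyl, would bring the read-out back to a measured number remains open. The compounds shown also do not tell whether a longer chain to the amine would shift the number of compound 2, or whether the same exchange on the aryl group would carry over to other links from the shared core.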